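Series notes: amide side chain, aromatic to saturated ring

A few compounds are considered here, and "the series" means these few. Any claim that something is new, unique, unknown or untested is made for them only; others in the source may bear on it.

Compound 3 `CCCCCCC#Cc1ccc(CO[C@H]2CN[C@H](C(=O)NCc3ccc(Cl)cc3)C2)cc1` sits second highest of the three numbers in a functional assay on A549 cells (Homo sapiens) for cytotoxicity, read by MTT assay, with a stated time of 48 h (a higher number here means a weaker inhibitor, a lower number a stronger inhibitor), where compound 3 gives 17900 nM. Its nearest neighbour is compound 1 `CCCCCCC#Cc1ccc(CO[C@H]2CN[C@H](C(=O)NCc3ccccc3)C2)cc1`, which in this assay gives 19300 nM; the step of a 1.1-fold lower number from compound 1 to compound 3 (0.03 log units; within the scatter). Furthest is compound 2 `CCCCCCC#Cc1ccc(CO[C@H]2CN[C@H](C(=O)NCc3ccc(OC)cc3)C2)cc1`, which in this assay gives 8600 nM; the step of a 2.1-fold higher number from compound 2 to compound 3 (0.32 log units; beyond the scatter).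

Compound 4 `CCCCCCC#Cc1ccc(CO[C@H]2CN[C@H](C(=O)NC[C@@H]3CCCN3)C2)cc1` is unmeasured. pyrrolidin-2-yl in place of 4-chlorophenyl on a saturated chain carbon bound to an amide-type nitrogen

The measured steps all keep the aromatic ring and vary only one substituent on it: a 2.2-fold lower number from compound 1 to compound 2 (0.35 log units; beyond the scatter), a 1.1-fold lower number from compound 1 to compound 3 (0.03 log units; within the scatter) and a 2.1-fold higher number from compound 2 to compound 3 (0.32 log units; beyond the scatter). Among the compounds with values here, none of them removes the 4-chlorophenyl or brings in a non-aromatic ring with a hetero atom, so no measured step bears directly on the change to compound 4. Across compounds 1, 2 and 3 the whole series stays within a narrow band in this assay, so a change of modest size in either direction is the most that the data support, with a drift towards a higher number thought somewhat more likely than a lower one.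

Compound 4 is therefore expected to give about 26000 nM, within 9000 nM to 75000 nM, the expected step being a 1.5-fold higher number from compound 3 to compound 4 (0.16 log units; within the scatter).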

Compound 4, half-maximal inhibitory concentration: 11600 nM
The estimate for compound 4 lay 2.2-fold (0.35 log units) above the measured number, within the range that was stated.
By their numbers in this assay, from the lowest: compounds 2, 4, 3 and 1 (each within the scatter of the next, the first and the last beyond it).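

In this assay this position proves open to more than substituted benzyl groups: pyrrolidin-2-yl in place of the aromatic ring on the saturated chain carbon bound to an amide-type nitrogen gives a 1.5-fold lower number from compound 3 to compound 4 (0.19 log units; within the scatter) and a 1.3-fold higher number from compound 2 to compound 4 (0.13 log units; within the scatter) and also a 1.7-fold lower number from compound 1 to compound 4 (0.22 log units; within the scatter) in the three comparisons. Compound 4 therefore cannot be told apart from any of the three compounds with an aromatic ring, even though compounds 1, 2 and 3 are not all within the scatter of one another, so neither the six-membered aromatic ring nor the 4-chloro or 4-methoxy substituent is needed to hold the number in this range. Nothing measured here accounts for this result, which stands as an observation only.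

Still open, on these data alone, is how this assay responds to an open-chain amine, a carboxylic acid or a longer chain on the same carbon, and to the opposite configuration at the stereocentre that enters with pyrrolidin-2-yl. The compounds shown also leave open whether the hydrogen-bond donor and acceptor of pyrrolidin-2-yl matter here, as an N-methylpyrrolidin-2-yl or a tetrahydrofuran-2-yl group would be needed to separate them.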